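Changing the Anilino Group: From Compound 2 to Compound 3

The source may report more compounds than this note shows. Statements on the series, on what has been measured and on what is new or still open speak of the compounds shown alone.

Of the compounds shown here, two sharing one core have been tested in a functional assay on MGC-803 cells (Homo sapiens) for cytotoxicity, read by MTT assay, with a stated time of 72 h; a higher number here means a weaker inhibitor, a lower number a stronger inhibitor. Compound 1 `CCCCCCCCCCCCCCNc1nc(SCc2ccc(C(F)(F)F)cc2)nc2ccccc12` reaches only the limit of > 50000 nM in this assay. Among the measured compounds shown here, compound 2 `Cc1ccccc1Nc1nc(SCc2ccc(C(F)(F)F)cc2)nc2ccccc12` gives 24400 nM in this assay, the only true number so far. The value of compound 1 is a limit (the limit of > 50000 nM in this assay, at which 1 of the 2 values shown sits). Compound 3 `COc1ccc(Nc2nc(SCc3ccc(C(F)(F)F)cc3)nc3ccccc23)c(OC)c1` differs from compound 2 in one place (2,4-dimethoxyphenyl in place of 2-methylphenyl on a nitrogen on an aromatic ring). For the measured compounds named here, no measured step covers a change of this kind, so the step from compound 2 to compound 3 is expected to be a 1.2-fold lower number from compound 2 to compound 3 (0.09 log units; within the scatter), within the usual scatter. Compound 3 is therefore estimated at 20000 nM in this assay, between 6000 nM and 60000 nM.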

Compound 3, half-maximal inhibitory concentration: > 50000 nM
Compound 3 ended at the assay's limit; the forecaster's own chance of this, stated with the estimate: 25%; at least 2.5-fold (0.39 log units) between middle value and limit.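

Among the compounds shown here, on the nitrogen on an aromatic ring, replacing 2-methylphenyl with 2,4-dimethoxyphenyl gives the first readable step in this assay: an at least 2.0-fold higher number from compound 2 to compound 3 (0.31 log units; beyond the scatter). This position therefore responds to the aryl group it carries, and the added methoxy groups do not bring a lower number. Little room remains for reading further changes: the limit of > 50000 nM in this assay, at which 2 of the 3 values shown sit.

As far as these compounds go, how far compound 3 lies past its limit remains open. So does whether a plain phenyl, or a phenyl carrying a single methoxy group or a chlorine, would give a lower number than compound 2.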